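The source may report more compounds than this note shows. Statements on the series, on what has been measured and on what is new or still open speak of the compounds shown alone.

Measured compounds in a functional assay on HepG2 cells (Homo sapiens) for inhibition, read by MTT assay, with a stated time of 72 h; a lower number here means a stronger inhibitor, a higher number a weaker inhibitor:
Compound 1 `O=c1cc(Cn2cc(C3CC3)nn2)c2ccc(O)cc2o1` gives > 100000 nM, a limit of the assay.
Compound 2 `O=c1cc(Cn2cc(CCCCl)nn2)c2ccc(O)cc2o1` gives > 100000 nM, a limit of the assay.
Compound 3 `CCCCCCCCc1cn(Cc2cc(=O)oc3cc(O)ccc23)nn1` gives 34200 nM.

Within the data shown here, compound 3 holds the only number in this assay; the other two values sit at the limit of > 100000 nM in this assay, at which 2 of the 3 values shown sit. The steps of an at least 2.9-fold lower number from compound 1 to compound 3 (0.46 log units; beyond the scatter) and an at least 2.9-fold lower number from compound 2 to compound 3 (0.46 log units; beyond the scatter) both go beyond the scatter once the octyl chain is present. Compound 4 `O=c1cc(Cn2cc(CSC(=S)N3CCNCC3)nn2)c2ccc(O)cc2o1` reverses that direction: a group of 9 heavy atoms (5 carbon, 2 nitrogen, 2 sulfur; one six-membered non-aromatic ring with 2 hetero atoms) in place of a group of 7 heavy atoms (7 carbon; no ring), on a saturated chain carbon bound to an aromatic carbon. Among the measured compounds shown here, no measured step covers the entering group, but every compound without the long chain sits at the limit, so compound 4 is expected to lose potency, with an estimated step of a 2.3-fold higher number from compound 3 to compound 4 (0.37 log units; beyond the scatter). For compound 4 the estimate is 80000 nM, within 20000 nM to 300000 nM, with a real chance that only a limit is reported.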

Compound 4, half-maximal inhibitory concentration: > 100000 nM
Compound 4 was reported as a limit; the forecaster's own chance of this, stated with the estimate: 55%; middle value at least 1.2-fold (0.09 log units) from the limit.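

In this assay, the group with the six-membered non-aromatic ring, in place of heptyl on a saturated chain carbon bound to an aromatic carbon, gives an at least 2.9-fold higher number from compound 3 to compound 4 (0.46 log units; beyond the scatter). A larger group on this carbon therefore does not by itself keep a readable number, since the entering group has more heavy atoms than heptyl. The step from compound 2 to compound 4 cannot be read, and compound 3 stays alone with a number: the limit of > 100000 nM in this assay, at which 3 of the 4 values shown sit.

On these data alone, whether a decyl chain would lower the number further remains open. So does whether an amine at the end of the octyl chain would keep it.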